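A few compounds are considered here, and "the series" means these few. Any claim that something is new, unique, unknown or untested is made for them only; others in the source may bear on it.

Among the measured compounds shown here, compound 3 `CCOC(=O)C(C)(C)CCCCOC(COCc1ccc(OC)cc1)Cn1ccnc1` stands at the top of the three numbers measured so far in a functional assay on a cell-free system (plasma) for inhibition of Thromboxane-A synthase (Homo sapiens); on this read-out lower numbers stand for stronger inhibition and higher numbers for weaker inhibition: compound 3 gives 17600 nM, while compound 1 `COc1ccc(COCC(Cn2ccnc2)OCCCCCC(=O)O)cc1` gives 560 nM and compound 2 `CCOC(=O)CCCCCOC(COCc1ccc(OC)cc1)Cn1ccnc1` gives 120 nM. The steps of a 31-fold higher number from compound 1 to compound 3 (1.50 log units; beyond the scatter) and a 150-fold higher number from compound 2 to compound 3 (2.17 log units; beyond the scatter) both set compound 3 well apart from the other two.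

Compound 4 `CCOC(=O)/C=C/CCCOC(COCc1ccc(OC)cc1)Cn1ccnc1` differs from compound 3 in one place: 2-(ethoxycarbonyl)ethenyl in place of 2-(ethoxycarbonyl)-2-methylpropyl on a saturated chain carbon, three bonds along the chain from an oxygen on a saturated carbon. The measured step that bears most directly on this is a 150-fold higher number from compound 2 to compound 3 (2.17 log units; beyond the scatter), where the 1-(ethoxycarbonyl)-1-methylethyl group entered in place of (ethoxycarbonyl)methyl. Compound 4 takes that group away again, and its chain is otherwise built like the chain of compound 2, apart from the added double bond. For the measured compounds named here, a large fall in the number is therefore expected, but no measured step covers the double bond, so the estimate is kept wide. In this assay compound 4 is expected to give 250 nM, between 60 nM and 1100 nM, an expected step of a 70-fold lower number from compound 3 to compound 4 (1.85 log units; beyond the scatter).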

Compound 4, half-maximal inhibitory concentration: 10000 nM
For compound 4 the middle estimate is 40-fold (1.60 log units) below the measured one; measured number above the stated range.
By their numbers in this assay, from the lowest: compound 2; then compound 1; then compounds 4 and 3 (each within the scatter of the next).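

The 2-(ethoxycarbonyl)ethenyl group does not restore the low number, and in this assay the step of a 1.8-fold lower number from compound 3 to compound 4 (0.25 log units; within the scatter) leaves compound 4 level with compound 3. Measured against the saturated 2-(ethoxycarbonyl)ethyl chain, the double bond gives an 83-fold higher number from compound 2 to compound 4 (1.92 log units; beyond the scatter) and, against the 2-carboxyethyl chain, an 18-fold higher number from compound 1 to compound 4 (1.25 log units; beyond the scatter), so at this place a double bond without the added methyl groups is enough to lose most of the inhibition seen in compound 2. Nothing measured here gives a reason for this loss.

The compounds shown leave open whether the loss belongs to the double bond as such, since a cis double bond or a triple bond at this place would test that. They also leave open how a free carboxylic acid or a longer chain would behave alongside the double bond.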